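Pyridinyl amide series: a positional isomer of compound 1

This account rests on a few compounds, and the source may have more. Where it says the series, first, only, none or still open, it means among the compounds named here.

Values measured in an ADME assay on MRC5 cells (Homo sapiens) for inhibition, with a stated time of 72 h; a higher number here means that more compound is needed for the effect, a lower number that less compound is needed:
Compound 1, `COc1cccc(OC)c1C(=O)Nc1c[nH]nc1C(=O)Nc1ccncc1`, gives > 50000 nM, which is a limit of the assay.
Compound 2, `CO[C@H]1CC[C@H](NC(=O)c2n[nH]cc2NC(=O)c2ccc(F)cc2F)CC1`, gives 11000 nM.
Compound 3, `CO[C@H]1CC[C@H](NC(=O)c2n[nH]cc2NC(=O)c2cc3ccccn3n2)CC1`, gives 1000 nM.

Compound 1 stands at the limit (the limit of > 50000 nM in this assay, at which 1 of the 3 values shown sits), so no number is available for it. Compound 4, `COc1cccc(OC)c1C(=O)Nc1c[nH]nc1C(=O)Nc1ccccn1`, carries pyridin-2-yl in place of pyridin-4-yl on an amide-type nitrogen. Going by the values given here, the only measured step, an 11-fold lower number from compound 2 to compound 3 (1.04 log units; beyond the scatter), changes the group on the carbonyl carbon of the other amide and so does not bear on the amide-type nitrogen altered here. Among the compounds with values here, no measured step touches this change, and compound 1 offers only a limit as a starting point. The step of a number no higher from compound 1 to compound 4 (the limit leaves the size open) is therefore expected to be none beyond the scatter. Compound 4 is estimated at 50000 nM in this assay, in a range from 15000 nM to 150000 nM, and is expected most likely to be reported again only as a limit.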

Compound 4, half-maximal effective concentration: > 50000 nM
Compound 4: a limit, no number; the forecaster's own chance of this, stated with the estimate: 75%; the middle value sits exactly at the limit.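

Compound 1 and compound 4 both stand at a limit in this assay, so no step can be read between them: the limit of > 50000 nM in this assay, at which 2 of the 4 values shown sit.

From the compounds shown here alone, whether pyridin-2-yl in place of pyridin-4-yl on the amide-type nitrogen shifts the number at all stays open.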